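A few compounds are considered here, and "the series" means these few. Any claim that something is new, unique, unknown or untested is made for them only; others in the source may bear on it.

In a physicochemical assay for solubility, read by HPLC, in phosphate buffer, measured as thermodynamic solubility, with a stated time of 48 h, at pH 7.2 (a higher number here means a more soluble compound, a lower number a less soluble compound), compound 1 `CCCOc1ccc(C[C@@H](Cc2ccccc2)C(=O)O)cc1CNC(=O)c1ccc(-c2ccncc2)cc1` gives 34.1 ug/mL. Compound 2 `CCCOc1ccc(C[C@@H](Cc2ccccc2)C(=O)O)cc1CNC(=O)c1ccc(-c2ccccc2C)cc1` carries a 2-methylphenyl on an aromatic carbon where compound 1 carries a pyridin-4-yl. In this assay compound 2 gives < 1 ug/mL, which is a limit of the assay rather than a measured number, the point described by the limit of < 1 ug/mL in this assay, at which 1 of the 2 values shown sits. The exchange of rings produced an at least 34-fold lower number from compound 1 to compound 2 (1.53 log units; beyond the scatter), so compound 2 stands at the floor of what this assay can report. Compound 3 `CCCOc1ccc(C[C@@H](Cc2ccccc2)C(=O)O)cc1CNC(=O)c1ccc(-c2ccccc2F)cc1` differs from compound 2 in one place: fluoro in place of methyl on an aromatic carbon. Going by the values given here, no measured step swaps methyl for fluoro, and the one step on record, which exchanged a whole ring, bears on this smaller change only loosely. The estimate is therefore a modest movement, an at least 1.5-fold higher number from compound 2 to compound 3 (0.17 log units; that floor lies within the scatter), with compound 3 staying close to the limit of this assay. For compound 3 in this assay the expected value is 1.5 ug/mL, with a likely range from 0.5 ug/mL to 6 ug/mL.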

Compound 3, solubility: < 1 ug/mL
Compound 3 was reported as a limit (the forecaster's own chance of this, stated with the estimate: 45%); at least 1.5-fold (0.17 log units) between middle value and limit.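

In this assay compound 3 gives < 1 ug/mL, which is a limit of the assay and not a number. Putting 2-fluorophenyl in place of pyridin-4-yl produces an at least 34-fold lower number from compound 1 to compound 3 (1.53 log units; beyond the scatter), so the large fall seen with the 2-methylphenyl ring also appears without the methyl group. The step from methyl to fluoro cannot be read, and whether the two groups differ at all stays hidden, because both compounds rest on the same floor: the limit of < 1 ug/mL in this assay, at which 2 of the 3 values shown sit.

From the compounds shown here alone, it remains open what an amine or a carboxylic acid at this place on the phenyl ring would give, and whether either would lift the number clear of the limit. Going by these compounds, how far compound 2 and compound 3 truly lie apart also stays unknown.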